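The source may hold more compounds than are shown below. What is called first, only, known or untested is meant among the compounds shown, and "the series" means these compounds.

In an ADME assay on HepG2 cells (Homo sapiens) for cytotoxicity, read by MTT assay, with a stated time of 72 h (a higher number here means that more compound is tolerated, a lower number that less compound is tolerated), compound 3 `O=[N+]([O-])c1c(CS(=O)(=O)c2ccccc2)nc2c(C#Cc3ccc(CO)cc3)cc(Cl)cn12` gives > 15600 nM, which is a limit and not a number. Compound 1 `O=[N+]([O-])c1c(CS(=O)(=O)c2ccccc2)nc2c(C#Cc3cccc(F)c3)cc(Cl)cn12` gives > 3900 nM, also a limit. Compound 2 `Nc1ccc(C#Cc2cc(Cl)cn3c([N+](=O)[O-])c(CS(=O)(=O)c4ccccc4)nc23)cc1` gives > 3900 nM, again a limit. Compound 4 `CC(O)(C#Cc1cc(Cl)cn2c([N+](=O)[O-])c(CS(=O)(=O)c3ccccc3)nc12)c1ccccc1` carries 1-hydroxy-1-phenylethyl in place of 4-(hydroxymethyl)phenyl on a triple-bonded carbon. The measured changes in this same group are a step that the two limits leave unreadable from compound 1 to compound 2, a step that the two limits leave unreadable from compound 1 to compound 3 and a step that the two limits leave unreadable from compound 2 to compound 3. None of them has a readable size, so they offer no basis for expecting a shift in this assay beyond the usual scatter. The expected change is an at least 1.1-fold lower number from compound 3 to compound 4 (0.04 log units; that floor lies within the scatter). For compound 4 the estimate is 14000 nM, with an expected range from 3900 nM to 40000 nM.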

Compound 4, half-maximal cytotoxic concentration: 18800 nM
Estimate against measurement, compound 4: 1.3-fold (0.13 log units) below; the range from low to high includes it.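

Compounds 1, 2 and 3 are known only as limits, not numbers, and the step from each of them to compound 4 cannot be read. The compounds shown leave open how compound 4 truly compares with these three in this assay.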